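From acetyl to methyl on compound 1

The source may hold more compounds than are shown below. What is called first, only, known or untested is meant among the compounds shown, and "the series" means these compounds.

In a physicochemical assay for solubility, at pH 7 (on this read-out lower numbers stand for lower solubility and higher numbers for higher solubility), compound 1 `CC(=O)N1CCN(C(=O)N2Cc3c(NC(=O)c4ccc(F)cc4)n[nH]c3C2(C)C)CC1` gives > 225000 nM, which is a limit and not a number. Compound 2 `CN1CCC(C(=O)N2Cc3c(NC(=O)NCc4ccccc4)n[nH]c3C2(C)C)CC1` gives > 225000 nM, also a limit. Compound 3 `CN1CCC(C(=O)N2Cc3c(NC(=O)c4cc(F)cc(F)c4)n[nH]c3C2(C)C)CC1` gives > 225000 nM, again a limit.

Compound 4 `CN1CCN(C(=O)N2Cc3c(NC(=O)c4ccc(F)cc4)n[nH]c3C2(C)C)CC1` carries methyl in place of acetyl on an amine nitrogen in a ring, 4-acetylpiperazin-1-yl to 4-methylpiperazin-1-yl: methyl in place of acetyl on an amine nitrogen in a ring. Going by the values given here, the only measured step is a step that the two limits leave unreadable from compound 2 to compound 3, and it offers no size to carry over. The expectation therefore rests on (the limit of > 225000 nM in this assay, at which 3 of the 3 values shown sit), and no step beyond the scatter is expected in this assay. The estimated step is a number no higher from compound 1 to compound 4 (the limit leaves the size open). Compound 4 is estimated at 225000 nM, with an expected range from 120000 nM to 450000 nM, and a report as a limit is likely.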

Compound 4, solubility: > 225000 nM
Compound 4: only a limit was reported; the forecaster's own chance of this, stated with the estimate: 85%; the middle value lies on the limit itself.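

Compound 1 and compound 4 are both reported only as limits in this assay, so no new step can be read. The compounds shown leave open whether acetyl and methyl on the ring nitrogen differ at all in this read-out: the limit of > 225000 nM in this assay, at which 4 of the 4 values shown sit.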